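This account rests on a few compounds, and the source may have more. Where it says the series, first, only, none or still open, it means among the compounds named here.

Values in a functional assay on HT-29 cells (Homo sapiens) for cytotoxicity, read by XTT assay, with a stated time of 72 h; a lower number here means a stronger inhibitor, a higher number a weaker inhibitor:
- compound 1 `COc1ccc(C(=O)c2cc(OC)c(OC)c(OC)c2)cc1[N+](=O)[O-]`: 2900 nM
- compound 2 `COc1ccc(Cc2cc(OC)c(OC)c(OC)c2)cc1O`: 440 nM
- compound 3 `COc1cc(Cc2ccc3ccccc3c2)cc(OC)c1OC`: 250 nM

Compound 1 has the highest number of the three and is the weakest, with its gaps to compound 2 and compound 3 beyond the scatter. Compound 4 `COc1ccc(C(=O)c2cc(OC)c(OC)c(OC)c2)cc1N` keeps the core of compound 1 and carries amino in place of nitro on an aromatic carbon, ortho to a methoxy group: amino in place of nitro on an aromatic carbon. Going by the values given here, no measured pair isolates this change. Compound 2, which has no nitro, gives 440 nM, though it also differs elsewhere. A downward step beyond the scatter is therefore expected, estimated as a 36-fold lower number from compound 1 to compound 4 (1.56 log units; beyond the scatter). For compound 4 the estimated value is 80 nM, with an expected range of 10 nM to 600 nM.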

Compound 4, half-maximal inhibitory concentration: 32 nM
The estimate for compound 4 lay 2.5-fold (0.40 log units) above the measured number; the range from low to high includes it.
By their numbers in this assay, from the lowest: compound 4; then compounds 3 and 2 (each within the scatter of the next); then compound 1.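

Going by these compounds alone, on the core of compound 1, the aromatic carbon ortho to a methoxy group is highly sensitive in this assay and amino in place of nitro gives a 91-fold lower number from compound 1 to compound 4 (1.96 log units; beyond the scatter) as the only single-place change read so far. This large step comes from that one change alone, with the rest of the structure held constant. No measured evidence accounts for its size.

As far as these compounds go, whether an acetamide or a dimethylamino group on this carbon would keep the number of compound 4 stays open. Also open, from the compounds shown here alone, is whether the same step would appear on a different core.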